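Pyrazolopyridine carbonitriles: aryl change at the nitrile-flanked position

The source may report more compounds than this note shows. Statements on the series, on what has been measured and on what is new or still open speak of the compounds shown alone.

Measured so far: compound 1 `COc1cc(-c2c(C#N)c(-c3ccco3)nc3c2c(-c2ccccc2)nn3-c2ccccc2)ccc1O` 35300 nM; compound 2 `COc1ccc(-c2c(C#N)c(-c3ccccc3)nc3c2c(-c2ccccc2)nn3-c2ccccc2)cc1OC` > 25000 nM.

In a functional assay on MV4-11 cells (Homo sapiens) for antiproliferative activity, read by resazurin assay, with a stated time of 72 h (a higher number here means a weaker inhibitor, a lower number a stronger inhibitor), compound 2 gives > 25000 nM, which is a limit of the assay rather than a number (the limit of > 25000 nM in this assay, at which 1 of the 2 values shown sits). Among the compounds with values here, compound 1 gives 35300 nM, the one numeric value. Compound 3 `N#Cc1c(-c2ccccc2)nc2c(c(-c3ccccc3)nn2-c2ccccc2)c1-c1ccc(O)cc1` carries 4-hydroxyphenyl in place of 3,4-dimethoxyphenyl on an aromatic carbon. Within the data shown here, no measured step exists for this change, so only a weak expectation is possible: compound 3 is expected to stay within the scatter of compound 2, with a step that the limit leaves unreadable from compound 2 to compound 3 as the estimated step. Compound 3 is estimated at 30000 nM, between 8000 nM and 100000 nM.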

Compound 3, half-maximal inhibitory concentration: 26100 nM
For compound 3 the middle estimate is 1.1-fold (0.06 log units) above the measured one, within the range that was stated.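

No step can be read between compound 2 and compound 3, because compound 2 stands at a limit of the assay: the limit of > 25000 nM in this assay, at which 1 of the 3 values shown sits.
As far as these compounds go, whether 4-hydroxyphenyl in place of 3,4-dimethoxyphenyl shifts activity at all remains open.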